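Dichlorobenzyl Ether in a Fused Pyrazolo Lactam Series

The compounds below may be only part of what the source reports. "The series", "measured", "known", "first", "only" and "open" are said of these compounds alone.

Compound 1 `Cc1nn(-c2ncnc3nc[nH]c23)c2c1C(c1ccc(OC(C)C)cc1)CC(=O)N2`: 18 nM
Compound 2 `Cc1nn(-c2ncnc3nc[nH]c23)c2c1C(OCc1ccc(C(C)C)cc1)CC(=O)N2`: 5 nM
Compound 3 `Cc1nn(-c2ncnc3nc[nH]c23)c2c1C(C(=O)N(C)c1nccs1)CC(=O)N2`: 18 nM

The three measured compounds share one core and differ only in the group on a saturated ring carbon. In a functional assay on HEK293 cells for agonist activity at G-protein coupled receptor 39 (Homo sapiens), read by scintillation proximity assay and inositol phosphate accumulation, with a stated time of 75 min, in the presence of a further agent that is not named here (on this read-out higher numbers stand for an effect only at larger amounts of compound and lower numbers for an effect already at smaller amounts), compound 3 gives 18 nM, level with compound 1 at the digits shown; together the two stand at the highest numbers of the set, while compound 2 at 5 nM sits a clear step lower, beyond the scatter.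

Compound 4 `Cc1nn(-c2ncnc3nc[nH]c23)c2c1C(OCc1ccc(Cl)cc1Cl)CC(=O)N2` carries (2,4-dichlorobenzyl)oxy in place of methyl(1,3-thiazol-2-yl)carbamoyl on a saturated ring carbon. Going by the values given here, the only single-place step measured so far, no change at the digits printed from compound 1 to compound 3 (within the scatter), shows that exchanging one group at this carbon for another need not move the number at all. Compound 2, however, also carries an ether at this same carbon and shows the lowest number of the three, so an expected downward step a 2.3-fold lower number from compound 3 to compound 4 (0.35 log units; beyond the scatter) seems reasonable for compound 4. Compound 4 is therefore estimated at 8 nM in this assay, with a range from 3 nM to 25 nM.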

Compound 4, half-maximal effective concentration: 4 nM
Beside the measured number, compound 4's estimate is 2.0-fold (0.30 log units) above it, within the range that was stated.
By their numbers in this assay, from the lowest: compounds 4 and 2 (each within the scatter of the next); then compounds 1 and 3 (each within the scatter of the next).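

In this assay, placing (2,4-dichlorobenzyl)oxy on the saturated ring carbon moves the number beyond the scatter, with a 4.5-fold lower number from compound 3 to compound 4 (0.65 log units; beyond the scatter) and a 4.5-fold lower number from compound 1 to compound 4 (0.65 log units; beyond the scatter), whereas the earlier exchange at this carbon left it unchanged. Within the benzyl ethers, 2,4-dichlorophenyl in place of 4-isopropylphenyl gives a 1.3-fold lower number from compound 2 to compound 4 (0.10 log units; within the scatter), so these two different benzyl groups cannot be told apart here. Nothing available explains why the number moves with the ether at this carbon.

The compounds shown leave open what an unsubstituted benzyl ether, a benzylamine or a longer chain between the oxygen and the aromatic ring would give at this carbon. Also open, from the compounds shown here alone, is how a single chlorine on that ring would compare with the two in compound 4.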